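The compounds below may be only part of what the source reports. "The series", "measured", "known", "first", "only" and "open" are said of these compounds alone.

Measured compounds in a functional assay on MCF7 cells (Homo sapiens) for cytotoxicity, read by MTT assay, with a stated time of 48 h; on this read-out higher numbers stand for weaker inhibition and lower numbers for stronger inhibition:

Compound 1 `COc1ccc(C(=O)C2Sc3nnc(-c4cc(OC)c(OC)c(OC)c4)n3NC2c2ccco2)cc1` gives a value that is a limit of the assay, > 100000 nM.
Compound 2 `COc1cc(-c2nnc3n2NC(c2ccco2)C(C(=O)c2ccc(F)c(F)c2)S3)cc(OC)c1OC` gives 73200 nM.
Compound 3 `COc1cc(-c2nnc3n2NC(c2ccco2)C(C(=O)c2ccc([N+](=O)[O-])cc2)S3)cc(OC)c1OC` gives a value that is a limit of the assay, > 100000 nM.

Compound 3 thus stands at the limit of this assay and no number for it is known; compound 1 sits at the same limit, as the note the limit of > 100000 nM in this assay, at which 2 of the 3 values shown sit, records, while compound 2 alone has a numeric value. The step to compound 4 `COc1cccc(C(=O)C2Sc3nnc(-c4cc(OC)c(OC)c(OC)c4)n3NC2c2ccco2)c1` is 3-methoxyphenyl in place of 4-nitrophenyl on a carbonyl carbon.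

The measured steps bearing on this change are all within or at the edge of the scatter: an at least 1.3-fold higher number from compound 2 to compound 3 (0.13 log units; that floor lies within the scatter), an at least 1.3-fold lower number from compound 1 to compound 2 (0.13 log units; that floor lies within the scatter), and the nitro-for-methoxy exchange gives a step that the two limits leave unreadable from compound 1 to compound 3. Every change at the aryl ketone so far has left the compounds near or at the limit. Compound 1, bearing 4-methoxyphenyl at the carbonyl carbon, is a limit value, and compound 4 carries a methoxyphenyl at the same place. No step beyond the scatter is therefore expected in this assay; the estimated step of a number no higher from compound 3 to compound 4 (the limit leaves the size open) is read as no change. For compound 4 the expected value is 100000 nM, with a range from 50000 nM to 300000 nM, most likely reported again as a limit.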

Compound 4, half-maximal inhibitory concentration: > 100000 nM
Compound 4 gave a limit, no number; the forecaster's own chance of this, stated with the estimate: 60%; the middle value lies on the limit itself.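

In this assay the carbonyl carbon now carries 3-methoxyphenyl as well as 4-methoxyphenyl and 4-nitrophenyl, and compound 1, compound 3 and compound 4 all return a limit rather than a number, so the limit is not confined to aryl groups substituted at the 4-position: the limit of > 100000 nM in this assay, at which 3 of the 4 values shown sit.

Set against compound 2, the only compound with a numeric value, the exchange gives an at least 1.3-fold higher number from compound 2 to compound 4 (0.13 log units; that floor lies within the scatter), so 3-methoxyphenyl and 3,4-difluorophenyl are not separated by any step beyond the scatter. The steps among compound 1, compound 3 and compound 4 cannot be read, since each joins two limits, and the series therefore gives no ranking of the methoxy and nitro groups at this place.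

Going by these compounds, how far compound 1, compound 3 and compound 4 lie beyond the limit stays open, and a more sensitive read-out or a higher tested concentration would be needed to tell them apart. Also open, on these data alone, is whether an amine or a carboxylic acid on the aryl ring at this carbonyl carbon, or any change elsewhere on the shared core, would give a clear numeric value in this assay.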